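Halogen Swap on a Thiourea Series Against the Vanilloid Receptor

A few compounds are considered here, and "the series" means these few. Any claim that something is new, unique, unknown or untested is made for them only; others in the source may bear on it.

Three thioureas have been measured in an assay on CHO cells for displacement of a labelled ligand from transient receptor potential cation channel subfamily V member 1 (Rattus norvegicus); a higher number here means a weaker inhibitor, a lower number a stronger inhibitor. Compound 1 `COc1cc(CNC(=S)NC(CCc2ccc(C(C)(C)C)cc2)COC(=O)C(C)(C)C)cc(Cl)c1O` gives 122 nM. Compound 2 `COc1cc(CNC(=S)NC(CCc2ccc(C(C)(C)C)cc2)COC(=O)C(C)(C)C)cc(I)c1O` gives 214 nM in this assay. The change between them, (iodo in place of chloro on an aromatic carbon), made a step of a 1.8-fold higher number from compound 1 to compound 2 (0.24 log units; within the scatter). Compound 3 `COc1cc(CNC(=S)NCc2ccc(C(C)(C)C)cc2)c(Cl)cc1O` has a core that differs from that of compound 1 in a way not broken down here. In this assay compound 3 gives 36.9 nM, the lowest of the three numbers; compound 1 stands nearest and compound 2 furthest, both beyond the scatter.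

Compound 4 `COc1cc(CNC(=S)NCc2ccc(C(C)(C)C)cc2)c(I)cc1O` has not yet been measured. It differs from compound 3 by iodo in place of chloro on an aromatic carbon. This is the same kind of change as that from compound 1 to compound 2, though not the same: in compound 1 the chloro sits ortho to a hydroxy group, meta to a large group and meta to a methoxy group, whereas in compound 3 it sits ortho to a large group, meta to a hydroxy group and para to a methoxy group. Because the step of a 1.8-fold higher number from compound 1 to compound 2 (0.24 log units; within the scatter) stayed within the scatter, a step of similar size, a 1.5-fold higher number from compound 3 to compound 4 (0.17 log units; within the scatter), is expected here. Compound 4 is therefore estimated at 55 nM, most likely between 20 nM and 150 nM.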

Compound 4, inhibition constant: 130 nM
Compound 4: the middle estimate sits 2.4-fold (0.37 log units) below what was measured, within the range that was stated.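

Iodo in place of chloro gave a 3.5-fold higher number from compound 3 to compound 4 (0.55 log units; beyond the scatter) in this assay, so on this core the swap leaves a weaker inhibitor, by a margin that the step on the core of compound 1 did not reach. Even so, the two steps cannot be told apart, and the change can be said to have carried from one core to the other at a similar size: the same change on two cores in this assay, a 1.8-fold higher number (0.24 log units; within the scatter) from compound 1 to compound 2 and a 3.5-fold higher number (0.55 log units; beyond the scatter) from compound 3 to compound 4, 2.0-fold (0.30 log units) apart, within the scatter of two such steps What this does not show is that the step has a fixed size, as there are only two pairs, the halogen sits at a different place on the ring in each, and two pairs give no rule for any further core.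

The compounds shown carry only chloro or iodo on this ring carbon, so how bromo, fluoro or a methyl group there would compare on either core stays open. Also open, on these data alone, is whether the step would hold with an amine in place of the hydroxy group.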